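The source may report more compounds than this note shows. Statements on the series, on what has been measured and on what is new or still open speak of the compounds shown alone.

In an ADME assay on NIH3T3 cells (Mus musculus) for cytotoxicity (a higher number here means that more compound is tolerated, a lower number that less compound is tolerated), compound 3 (`Fc1cccc(COc2ccc(Nc3ncnc4sc(C#CCN5CCNCC5)cc34)cc2Cl)c1`) gives 3.9 uM and compound 1 (`CN1CCN(CC#Cc2cc3c(Nc4ccc(OCc5cccc(F)c5)c(Cl)c4)ncnc3s2)CC1`) gives 6.7 uM. These two values sit close together, with a 1.7-fold lower number from compound 1 to compound 3 (0.24 log units; within the scatter). Compound 2 (`CCOC(=O)CN(C)CC#Cc1cc2c(Nc3ccc(OCc4cccc(F)c4)c(Cl)c3)ncnc2s1`) gives > 50 uM, and this is a limit of the assay, not a number.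

Compound 4 (`COCC#Cc1cc2c(Nc3ccc(OCc4cccc(F)c4)c(Cl)c3)ncnc2s1`) has not yet been measured. It carries methoxy in place of piperazin-1-yl on a saturated chain carbon bound to a triple-bonded carbon.

Among the measured compounds shown here, two measured steps bear on this change, as both exchange a piperazine ring against an open-chain group: an at least 7.4-fold higher number from compound 1 to compound 2 (0.87 log units; beyond the scatter), and an at least 12-fold lower number from compound 2 to compound 3 (1.10 log units; beyond the scatter). In both, the ring goes with the lower number. However, only one open-chain group has been tested, it differs from methoxy, and its result is a limit, so the size of the change is only loosely expected. A rise beyond the scatter is expected in this assay, estimated as a 5.1-fold higher number from compound 3 to compound 4 (0.71 log units; beyond the scatter). For compound 4 the estimated value is 20 uM, with an expected range of 7 uM to 50 uM.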

Compound 4, half-maximal toxic concentration: 1.7 uM
Compound 4: middle estimate off by 12-fold (1.07 log units), on the high side, and the stated range ends above it.
By their numbers in this assay, from the lowest: compound 4; then compounds 3 and 1 (each within the scatter of the next). At a limit, above all of these: compound 2.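

In this assay, losing the piperazine ring does not raise the number: replacing it with methoxy gives a 2.3-fold lower number from compound 3 to compound 4 (0.36 log units; beyond the scatter), and replacing the methylated ring gives a 3.9-fold lower number from compound 1 to compound 4 (0.60 log units; beyond the scatter). The earlier link between the ring and the lower number therefore does not hold across the series, and compound 4, which has no ring at this place, goes against it. The ((ethoxycarbonyl)methyl)(methyl)amino group alone stands apart, with an at least 29-fold lower number from compound 2 to compound 4 (1.46 log units; beyond the scatter), and that step rests on a limit, not a number: the limit of > 50 uM in this assay, at which 1 of the 4 values shown sits.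

As far as these compounds go, it stays open whether the high tolerance of compound 2 comes from its ethoxycarbonyl part or from its open-chain amine. A dimethylamino group or a carboxylic acid on the same saturated chain carbon would bear on that question.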